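From hydroxy to azido: one untested step

A few compounds are considered here, and "the series" means these few. Any claim that something is new, unique, unknown or untested is made for them only; others in the source may bear on it.

Going by the values given here, only one of the three compounds tested so far yields a number. In a functional assay on L6 cells (Rattus norvegicus) for cytotoxicity (on this read-out higher numbers stand for weaker inhibition and lower numbers for stronger inhibition), compound 1 (`O=c1ccn(CCCCO[Si](c2ccccc2)(c2ccccc2)c2ccccc2)c(=O)[nH]1`) has the entry "not determined" (no result reported) and compound 2 (`O=c1ccn(CCCCCCO)c(=O)[nH]1`) has the entry "not determined" (no result reported) as its record. Compound 3 (`O=c1ccn(CC(CO)CCOC(c2ccccc2)(c2ccccc2)c2ccccc2)c(=O)[nH]1`) gives 33000 nM in this assay and so stands alone as the single reference point. Compound 4 (`[N-]=[N+]=NCC(CCOC(c1ccccc1)(c1ccccc1)c1ccccc1)Cn1ccc(=O)[nH]c1=O`) differs from compound 3 in one place (azido in place of hydroxy on a saturated chain carbon, three bonds along the chain from an aromatic nitrogen), with azido in place of hydroxy on a saturated chain carbon, three bonds along the chain from an aromatic nitrogen. Among the compounds with values here, no measured pair shows what this swap does, so the expected step of a 1.3-fold lower number from compound 3 to compound 4 (0.12 log units; within the scatter) is none beyond the usual scatter of this assay in either direction. The estimate for compound 4 is 25000 nM within an expected range of 8000 nM to 80000 nM until the measurement arrives.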

Compound 4, half-maximal inhibitory concentration: 18000 nM
Compound 4: the middle estimate sits 1.4-fold (0.14 log units) above what was measured; low and high end bracket the measured number.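

In this assay the swap of hydroxy for azido gives a 1.8-fold lower number from compound 3 to compound 4 (0.26 log units; within the scatter) and so leaves the two compounds indistinguishable on this read-out. At this place on the chain, the hydrogen-bond donor of the hydroxy group can therefore give way to the three nitrogen atoms of azido with no change beyond the scatter. Nothing available explains this result.

On these data alone, whether an amine or a carboxylic acid on this carbon would also leave the number where it is remains open. So does the outcome of a longer chain carrying the azido group.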